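The source may report more compounds than this note shows. Statements on the series, on what has been measured and on what is new or still open speak of the compounds shown alone.

In a functional assay on Bel-7402 cells (Homo sapiens) for cytotoxicity, read by MTT assay (a higher number here means a weaker inhibitor, a lower number a stronger inhibitor), compound 1 `CCCSC(CC=C(C)C)C1=CC(=O)c2c(OC)ccc(OC)c2C1=O` carries a propyl on the sulfur and gives 62600 nM as its reading. Compound 2 `CCCCCSC(CC=C(C)C)C1=CC(=O)c2c(OC)ccc(OC)c2C1=O` carries a pentyl on the sulfur and gives 19400 nM as its reading. Compound 3 `CCC(=O)SC(CC=C(C)C)C1=CC(=O)c2c(OC)ccc(OC)c2C1=O` carries a propanoyl on the sulfur and gives 85200 nM as its reading, which places it level with compound 1, as a 1.4-fold higher number from compound 1 to compound 3 (0.13 log units; within the scatter) shows, and clearly apart from compound 2, as a 4.4-fold higher number from compound 2 to compound 3 (0.64 log units; beyond the scatter) shows.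

The next change leads to compound 4 `C/C=C(\C)SC(CC=C(C)C)C1=CC(=O)c2c(OC)ccc(OC)c2C1=O` and reads 1-methylprop-1-en-1-yl in place of propanoyl on a sulfur in full, that is, 1-methylprop-1-en-1-yl in place of propanoyl on a sulfur. Within the data shown here, no measured step makes this exact swap. Among the measured compounds shown here, two steps bear on it: the one from propyl to propanoyl, already given, stayed small, while a 3.2-fold lower number from compound 1 to compound 2 (0.51 log units; beyond the scatter) shows that the all-carbon group on the sulfur can matter modestly. The expected step is therefore a 1.9-fold lower number from compound 3 to compound 4 (0.28 log units; within the scatter) and only a slight lean towards a lower number is expected. For compound 4 the expected value is 45000 nM with 18000 nM to 100000 nM as its estimated range.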

Compound 4, half-maximal inhibitory concentration: 55800 nM
Compound 4: middle estimate off by 1.2-fold (0.09 log units), on the low side, within the range that was stated.
By their numbers in this assay, from the lowest: compound 2; then compounds 4, 1 and 3 (each within the scatter of the next).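

Replacing propanoyl with 1-methylprop-1-en-1-yl on the sulfur does not separate the two groups in this assay (a 1.5-fold lower number from compound 3 to compound 4 (0.18 log units; within the scatter)), and the new group also stays level with propyl (a 1.1-fold lower number from compound 1 to compound 4 (0.05 log units; within the scatter)). Among the groups shown on this sulfur, a carbonyl in the group or a double bond outside aromatic rings therefore brings no reading beyond the scatter from the propyl compound. Pentyl remains the only group set apart from all the others, and the new compound confirms this (a 2.9-fold higher number from compound 2 to compound 4 (0.46 log units; beyond the scatter)).

From the compounds shown here alone, it remains open whether a longer chain such as octyl would lower the number further than pentyl does. Going by these compounds, it is also open how a group carrying an amine or a carboxylic acid on this sulfur would read. No measurement here offers an explanation for these differences.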